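Working notes: an isomeric swap from compound 2

This account rests on a few compounds, and the source may have more. Where it says the series, first, only, none or still open, it means among the compounds named here.

Measured in a functional assay on NCI/ADR cells (Homo sapiens) for cytotoxicity, read by sulforhodamine B assay; a higher number here means a weaker inhibitor of growth, a lower number a stronger inhibitor of growth:
- Compound 1 `CC1=CC[C@@H]([C@@](C)(O)CCCC(C)(C)NC=S)CC1`: > 100000 nM (a limit of the assay)
- Compound 2 `CC1=CC[C@@H]([C@@](C)(O)CCCC(C)(C)NC(=S)N/N=C\c2ccc(C)cc2)CC1`: 30500 nM
- Compound 3 `CC1=CC[C@@H]([C@@](C)(O)CCCC(C)(C)NC(=S)N/N=C\c2ccc(Cl)cc2)CC1`: 36400 nM

Going by the values given here, compound 2, at 30500 nM, sits within the scatter of compound 3, at 36400 nM, which is the only other true number in the set. The value of compound 1 is a limit and gives no number to compare.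

Compound 4 `CC1=CC[C@@H]([C@@](C)(O)CCCC(C)(C)NC(=S)N/N=C(/C)c2ccccc2)CC1` is still to be measured. Compared with compound 2, the change is a group of 9 heavy atoms (8 carbon, 1 nitrogen; one six-membered aromatic ring of carbon only) in place of a group of 9 heavy atoms (8 carbon, 1 nitrogen; one six-membered aromatic ring of carbon only), on an amide-type nitrogen. The two compounds have the same atoms, joined differently, and the change sits on an amide-type nitrogen.

Among the compounds with values here, only one measured step bears on this, and only indirectly, since it is a different change: chloro in place of methyl on an aromatic carbon gave a 1.2-fold higher number from compound 2 to compound 3 (0.08 log units; within the scatter), which lies within the scatter. Within the data shown here, no measured step tests the rearrangement itself, so the range is kept wide. In this assay, the expected step is a 1.0-fold higher number from compound 2 to compound 4 (0.02 log units; within the scatter), with no expected change beyond the scatter and no preferred direction. The estimate for compound 4 is 32000 nM, with an expected range of 13000 nM to 75000 nM.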

Compound 4, concentration for total growth inhibition: > 100000 nM
Compound 4 was reported as a limit; the forecaster's own chance of this, stated with the estimate: 10%; middle value at least 3.1-fold (0.49 log units) from the limit.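

In this assay, exchanging one group of 9 heavy atoms for its isomer on an amide-type nitrogen gives an at least 3.2-fold higher number from compound 2 to compound 4 (0.51 log units; beyond the scatter), and the comparison with the chloro analogue gives an at least 2.7-fold higher number from compound 3 to compound 4 (0.43 log units; beyond the scatter). Both steps lie beyond the scatter, whereas chloro in place of methyl on an aromatic carbon gave a 1.2-fold higher number from compound 2 to compound 3 (0.08 log units; within the scatter), so this series tolerated that substituent exchange but not this rearrangement of the same atoms. Compound 4 is reported only as a limit, so both new steps give a minimum size and not a full one: the limit of > 100000 nM in this assay, at which 2 of the 4 values shown sit.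

The compounds shown do not separate the two parts of the rearrangement, so it remains unresolved whether the step follows from the methyl leaving the aromatic ring or from the altered group as a whole. Going by these compounds, it is also open whether an amine or a carboxylic acid in place of the aromatic methyl of compound 2 would keep the value within the scatter of compound 2, or would move it in either direction.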